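Adding an Ethoxy Group to a Hydrazone Antiproliferative Series

A few compounds are considered here, and "the series" means these few. Any claim that something is new, unique, unknown or untested is made for them only; others in the source may bear on it.

Compound 1 `O=C(N/N=C/c1ccccn1)c1cccc(S(=O)(=O)N2CCOCC2)c1`: 81700 nM
Compound 2 `O=C(N/N=C/c1ccccc1O)c1cccc(S(=O)(=O)N2CCOCC2)c1`: 25300 nM

Among the measured compounds shown here, in a functional assay on MGC-803 cells (Homo sapiens) for antiproliferative activity, read by MTT assay, with a stated time of 72 h (on this read-out lower numbers stand for stronger inhibition and higher numbers for weaker inhibition), compound 2 gives the lower of the two numbers measured so far. For the measured compounds named here, the only measured step, a 3.2-fold lower number from compound 1 to compound 2 (0.51 log units; beyond the scatter), came from replacing pyridin-2-yl with 2-hydroxyphenyl, and it was modest. Compound 3 `CCOc1cccc(/C=N/NC(=O)c2cccc(S(=O)(=O)N3CCOCC3)c2)c1O` differs from compound 2 by ethoxy in place of hydrogen on an aromatic carbon, turning 2-hydroxyphenyl into 3-ethoxy-2-hydroxyphenyl. Going by the values given here, no measured step involves an ethoxy group, so the single known step gives no direct guide; only a small change, possibly within the scatter, is expected. Compound 3 is therefore estimated at 15000 nM, in the range 5000 nM to 50000 nM, which would be a step of a 1.7-fold lower number from compound 2 to compound 3 (0.23 log units; within the scatter).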

Compound 3, half-maximal inhibitory concentration: 18000 nM
Estimate against measurement, compound 3: 1.2-fold (0.08 log units) below, and the stated range covers the measured number.
By their numbers in this assay, from the lowest: compounds 3 and 2 (each within the scatter of the next); then compound 1.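

In this assay putting ethoxy in place of hydrogen, on the aromatic carbon ortho to the hydroxy group, gives only a small step (a 1.4-fold lower number from compound 2 to compound 3 (0.15 log units; within the scatter)), so this position accepts the added group with no change that stands clear of the scatter. Replacing pyridin-2-yl with 3-ethoxy-2-hydroxyphenyl gives a larger step (a 4.5-fold lower number from compound 1 to compound 3 (0.66 log units; beyond the scatter)). Nothing available explains either step. Going by these compounds, whether a longer chain such as butoxy or an amine at this position would shift activity stays open. So does whether ethoxy would act alike on the pyridine-bearing compound 1.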